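The source may hold more compounds than are shown below. What is called first, only, known or untested is meant among the compounds shown, and "the series" means these compounds.

Of the compounds shown here, three built on a shared core have been measured in an assay (Canis lupus familiaris) for binding affinity to platelet-activating factor receptor (Homo sapiens), read by radioligand binding; a lower number here means a stronger inhibitor, a higher number a weaker inhibitor. Compound 1 `CC[C@H](CCCc1cccnc1)NC(=O)/C=C/C=C(c1ccc(OC)cc1)c1ccc(OC)cc1` gives 120 nM, the lowest of the three numbers. Compound 2 `O=C(/C=C\C=C(c1ccccc1)c1ccccc1)NCCCCc1cccnc1` gives 400 nM, and compound 3 `O=C(C=C(c1ccccc1)c1ccccc1)NCCCCc1cccnc1` gives 450 nM; both stand beyond the scatter from compound 1. Compound 4 `COc1ccc(C(=C/C=C/C(=O)N[C@@H](CCCc2cccnc2)C2CC2)c2ccc(OC)cc2)cc1` has not yet been measured in this assay. It differs from compound 1 by cyclopropyl in place of ethyl on a saturated chain carbon bound to an amide-type nitrogen and a saturated chain carbon. Among the compounds with values here, no measured pair shows this change, so nothing is known about its size here; the expectation is a step within the scatter, in no settled direction. Compound 4 is therefore estimated at 110 nM, with a range from 40 nM to 300 nM. The expected step is a 1.1-fold lower number from compound 1 to compound 4 (0.04 log units; within the scatter).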

Compound 4, half-maximal inhibitory concentration: 60 nM
Compound 4: middle estimate off by 1.8-fold (0.26 log units), on the high side; the range from low to high includes it.
By their numbers in this assay, from the lowest: compounds 4 and 1 (each within the scatter of the next); then compounds 2 and 3 (each within the scatter of the next).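

In this assay the step with cyclopropyl in place of ethyl on this saturated chain carbon is a 2.0-fold lower number from compound 1 to compound 4 (0.30 log units; within the scatter) and so gives no firm difference between the two groups. Within the data shown here, this is the first pair to test this position directly, and it shows that the position accepts a three-membered ring while the number stays within the scatter. Nothing here bears on why the two groups read alike.

From the compounds shown here alone, whether a cyclobutyl group, a longer chain or an amine at this carbon would be accepted remains open. Going by these compounds, a hydrogen at this carbon also remains untested on the core of compound 1.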